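The source may hold more compounds than are shown below. What is called first, only, known or untested is meant among the compounds shown, and "the series" means these compounds.

Measured in a functional assay on MCF7 cells (Homo sapiens) for antiproliferative activity, with a stated time of 72 h; on this read-out higher numbers stand for weaker inhibition and lower numbers for stronger inhibition:
- Compound 1 `C/C(=C\c1csc(C)n1)[C@@H]1C[C@@H]2OC(c3ccc(C)cc3)=N[C@H]2CCC[C@H](C)[C@H](O)[C@@H](C)C(=O)C(C)(C)[C@@H](O)CC(=O)O1`: 1.9 nM
- Compound 2 `CCc1ccc(C2=N[C@H]3CCC[C@H](C)[C@H](O)[C@@H](C)C(=O)C(C)(C)[C@@H](O)CC(=O)O[C@H](/C(C)=C/c4csc(C)n4)C[C@@H]3O2)cc1`: 297 nM
- Compound 3 `C/C(=C\c1csc(C)n1)[C@@H]1C[C@@H]2OC(c3ccc(C(C)C)cc3)=N[C@H]2CCC[C@H](C)[C@H](O)[C@@H](C)C(=O)C(C)(C)[C@@H](O)CC(=O)O1`: 5140 nM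

Compound 3 stands highest of the three, the weakest inhibitor so far. Compound 4 `C/C(=C\c1csc(C)n1)[C@@H]1C[C@@H]2OC(c3cccnc3)=N[C@H]2CCC[C@H](C)[C@H](O)[C@@H](C)C(=O)C(C)(C)[C@@H](O)CC(=O)O1` has pyridin-3-yl in place of 4-isopropylphenyl on a carbon with a double bond to nitrogen. Across the measured compounds, the number climbs as methyl gives way to ethyl and then isopropyl on the aromatic ring, with a 160-fold higher number from compound 1 to compound 2 (2.19 log units; beyond the scatter), a 17-fold higher number from compound 2 to compound 3 (1.24 log units; beyond the scatter) and overall a 2700-fold higher number from compound 1 to compound 3 (3.43 log units; beyond the scatter). For the measured compounds named here, no measured compound carries a ring nitrogen, so these steps bear only partly on the change. With the isopropyl gone, a large step towards a lower number is expected, recovering much of a 2700-fold higher number from compound 1 to compound 3 (3.43 log units; beyond the scatter) but not all of it. The expected change is a 170-fold lower number from compound 3 to compound 4 (2.23 log units; beyond the scatter). Compound 4 is estimated at 30 nM, within a range of 3 nM to 300 nM.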

Compound 4, half-maximal inhibitory concentration: 1.3 nM
Compound 4: middle estimate off by 23-fold (1.36 log units), on the high side; the measured number lies below the stated range.
By their numbers in this assay, from the lowest: compounds 4 and 1 (each within the scatter of the next); then compound 2; then compound 3.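

In this assay, at this carbon with a double bond to nitrogen, pyridin-3-yl gives a 4000-fold lower number from compound 3 to compound 4 (3.60 log units; beyond the scatter) and a 230-fold lower number from compound 2 to compound 4 (2.36 log units; beyond the scatter), whereas replacing 4-methylphenyl gives a 1.5-fold lower number from compound 1 to compound 4 (0.16 log units; within the scatter). The site therefore tolerates a six-membered aromatic ring with a hetero atom and a hydrogen-bond acceptor, which the earlier all-carbon aryl groups could not show. Nothing here explains these differences.

As far as these compounds go, it remains open how unsubstituted phenyl, pyridin-4-yl or 4-aminophenyl would compare at this carbon. Also open, from the compounds shown here alone, is whether a methyl, ethyl or isopropyl group on the pyridin-3-yl ring would change the number.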